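Compound 3 to compound 4: trimming the amine chain

A few compounds are considered here, and "the series" means these few. Any claim that something is new, unique, unknown or untested is made for them only; others in the source may bear on it.

In a functional assay on PC-3 cells (Homo sapiens) for antiproliferative activity, with a stated time of 72 h (on this read-out higher numbers stand for weaker inhibition and lower numbers for stronger inhibition), compound 3 (`COc1cc(OC)c(C(=O)/C=C/c2ccccc2Cl)c(O)c1CN(C)CCCN(C)C`) gives 14500 nM and holds the highest number of the three measured compounds. On the same read-out compound 1 (`COc1cc(OC)c(C(=O)/C=C/c2ccccc2Cl)c(O)c1CN1CCCC1`) gives 3100 nM and compound 2 (`COc1cc(OC)c(C(=O)/C=C/c2ccccc2Cl)c(O)c1CN1CCCCC1`) gives 1700 nM, and the gap between these two is small (a 1.8-fold lower number from compound 1 to compound 2 (0.26 log units; within the scatter)).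

Compound 4 (`COc1cc(OC)c(C(=O)/C=C/c2ccccc2Cl)c(O)c1CN(C)C`) is still unread. Its difference from compound 3 is hydrogen in place of 2-(dimethylamino)ethyl on a saturated chain carbon bound to an amine nitrogen, so that (3-(dimethylamino)propyl)(methyl)amino becomes dimethylamino.

Within the data shown here, no measured step makes this exact change. The closest evidence comes from two steps that install the same (3-(dimethylamino)propyl)(methyl)amino group in place of a cyclic amine (a 4.7-fold higher number from compound 1 to compound 3 (0.67 log units; beyond the scatter) and an 8.5-fold higher number from compound 2 to compound 3 (0.93 log units; beyond the scatter)). Both are modest, and both raise the number. Compound 4 loses the 2-(dimethylamino)ethyl portion, so a return towards the level of compound 1 at 3100 nM seems likely, although an open dimethylamino group has not been tested in this set. In this assay a modest drop in the number is therefore expected, and the estimate is a 3.6-fold lower number from compound 3 to compound 4 (0.56 log units; beyond the scatter) for this step. Compound 4 is expected at 4000 nM (estimated range 1600 nM to 10000 nM).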

Compound 4, half-maximal inhibitory concentration: 400 nM
Estimate against measurement, compound 4: 10-fold (1.00 log units) above, and the stated range ends above it.
By their numbers in this assay, from the lowest: compound 4; then compounds 2 and 1 (each within the scatter of the next); then compound 3.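

Cutting the 2-(dimethylamino)ethyl portion away in this assay gives a 36-fold lower number from compound 3 to compound 4 (1.56 log units; beyond the scatter), the largest step in the series, and it carries the number past the cyclic amines instead of back to their level, with a 4.3-fold lower number from compound 2 to compound 4 (0.63 log units; beyond the scatter) and a 7.8-fold lower number from compound 1 to compound 4 (0.89 log units; beyond the scatter). The earlier compounds showed an open amine only as a change for the worse on the saturated chain carbon bound to an aromatic carbon, whereas among these four compounds the two open amines now stand at opposite ends, with dimethylamino lowest, (3-(dimethylamino)propyl)(methyl)amino highest and the pyrrolidin-1-yl and piperidin-1-yl compounds in the middle, so an open amine at this place does not by itself raise the number. Nothing available explains the size of this step.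

The compounds shown leave open whether a diethylamino group or a morpholin-4-yl ring at this place would fall with compound 4 or with compound 1 and compound 2. From the compounds shown here alone, they also leave open how the number moves along a chain of intermediate length ending in dimethylamino, so the shape of the change from dimethylamino to the longer chain remains unknown.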